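Adding methoxymethyl to compound 2: working notes

The compounds below may be only part of what the source reports. "The series", "measured", "known", "first", "only" and "open" are said of these compounds alone.

In an ADME assay on microsomes from liver (Homo sapiens) for metabolic stability, with a stated time of 30 min, tested at 0.5 mg/mL (on this read-out higher numbers stand for a more stable compound and lower numbers for a less stable compound), compound 2 (`NC(=O)c1sc2nccc(N3CCCCC3)c2c1N`) gives 20% and stands level, within the scatter, with compound 1 (`CC1CCCN(c2ccnc3sc(C(N)=O)c(N)c23)C1`) at 18% on the same read-out. The two numbers do not separate these compounds.

Compound 3 (`COCC1CCCN(c2ccnc3sc(C(N)=O)c(N)c23)C1`) carries methoxymethyl in place of hydrogen on a saturated ring carbon, two ring bonds from the ring nitrogen, and the counted difference methoxymethyl in place of hydrogen on a saturated ring carbon sets it apart from compound 2.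

Within the data shown here, the one measured step that bears on this change is a number 2 percentage points higher from compound 1 to compound 2 (within the scatter) for hydrogen in place of methyl on a saturated ring carbon. That step is small, but it concerns methyl only. Among the measured compounds shown here, no measured compound carries methoxymethyl, so it is a thin guide, and the range has to stay wide on both sides.

Resting on that step, no shift beyond the scatter is expected in this assay and the estimated step is a number 2 percentage points lower from compound 2 to compound 3 (within the scatter) with no firm direction. In this assay the estimate for compound 3 is 18% with an expected range of 8% to 34% for the coming measurement.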

Compound 3, percent of the compound remaining: 66%
The estimate for compound 3 lay 48 percentage points below the measured number; measured number above the stated range.
By their numbers in this assay, from the lowest: compounds 1 and 2 (each within the scatter of the next); then compound 3.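

In this assay, the saturated ring carbon two ring bonds from the ring nitrogen proves able to carry a large change: methoxymethyl in place of hydrogen brings a number 46 percentage points higher from compound 2 to compound 3 (beyond the scatter), whereas the methyl pair showed only a number 2 percentage points higher from compound 1 to compound 2 (within the scatter). Read against the methyl-bearing compound, methoxy in place of hydrogen on a saturated chain carbon bound to a saturated ring carbon brings a number 48 percentage points higher from compound 1 to compound 3 (beyond the scatter), so among these compounds the rise appears only with the methoxy present and not with the added carbon alone. No measurement available here accounts for a step of this size.

Methoxymethyl is the only oxygen-bearing group shown at this position, which leaves open whether hydroxymethyl, ethyl or a longer ether chain on the same ring carbon would give a similar number in this assay. It is also open whether methoxymethyl would give a comparable step on another carbon of the ring, since the compounds shown carry it at this one place only.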